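Oxygen-linked aryl and benzyl groups on a shared core

A few compounds are considered here, and "the series" means these few. Any claim that something is new, unique, unknown or untested is made for them only; others in the source may bear on it.

Measured so far, in a functional assay for agonist activity at Free fatty acid receptor 1 (Homo sapiens), read by FLIPR, in the presence of a further agent that is not named here; a higher number here means that more compound is needed for the effect, a lower number that less compound is needed:
compound 1 `Cc1ccnc(Oc2ccc(CC3SC(=O)NC3=O)cc2)c1`: 4280 nM
compound 2 `Cc1ccc(Oc2ccc(CC3SC(=O)NC3=O)cc2)nc1`: 4470 nM
compound 3 `O=C1NC(=O)C(Cc2ccc(OCc3ccccc3)cc2)S1`: 6180 nM

The three compounds share one core and differ only in the group carried on the oxygen on the aromatic ring. Compound 3 carries the benzyl group and is set apart from the two pyridinyl-bearing compounds by a 1.4-fold higher number from compound 1 to compound 3 (0.16 log units; within the scatter) and a 1.4-fold higher number from compound 2 to compound 3 (0.14 log units; within the scatter), both within the scatter of this assay ; the three numbers are therefore not distinguished from one another, and the two pyridinyl variants, linked by a 1.0-fold higher number from compound 1 to compound 2 (0.02 log units; within the scatter), are equally indistinguishable.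

Compound 4 `O=C1NC(=O)C(Cc2ccc(Oc3ccc(F)cc3)cc2)S1` is the next member and is not yet measured. The change from compound 3 is 4-fluorophenyl in place of benzyl on an oxygen on an aromatic ring. For the measured compounds named here, the steps that bear on it are those in which a ring-bearing group on that oxygen was exchanged, namely a 1.4-fold higher number from compound 1 to compound 3 (0.16 log units; within the scatter) and a 1.4-fold higher number from compound 2 to compound 3 (0.14 log units; within the scatter), neither of which moved the number beyond the scatter. The expected step in this assay is therefore a 1.2-fold lower number from compound 3 to compound 4 (0.09 log units; within the scatter), nothing beyond the scatter. Compound 4 is estimated at 5000 nM, with a range from 2000 nM to 15000 nM.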

Compound 4, half-maximal effective concentration: 480 nM
For compound 4 the middle estimate is 10-fold (1.02 log units) above the measured one; measured number outside the range, below it.
By their numbers in this assay, from the lowest: compound 4; then compounds 1, 2 and 3 (each within the scatter of the next).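

On the oxygen on an aromatic ring, the group is not interchangeable in this assay: 4-fluorophenyl in place of benzyl gives a 13-fold lower number from compound 3 to compound 4 (1.11 log units; beyond the scatter), and the same group also stands apart from both pyridinyl variants, with a 9.3-fold lower number from compound 2 to compound 4 (0.97 log units; beyond the scatter) and an 8.9-fold lower number from compound 1 to compound 4 (0.95 log units; beyond the scatter). Benzyl and 4-fluorophenyl match in heavy-atom count and each holds one six-membered aromatic ring of carbon only, so these counts do not separate two groups whose numbers differ beyond the scatter. No measurement in hand accounts for this step.

Still open, going by these compounds, is whether the step belongs to the fluorine or to the phenyl ring itself, which a plain phenyl group on that oxygen would separate. Also open, on these data alone, is how a 4-chlorophenyl or 4-methoxyphenyl group would read there.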